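A few compounds are considered here, and "the series" means these few. Any claim that something is new, unique, unknown or untested is made for them only; others in the source may bear on it.

Compound 1 `CC1=C(C(=O)OC(C)(C)C)C(c2csc(-c3ccc(Cl)cc3)n2)C(C(=O)OC(C)(C)C)=C(C)N1` is one of three compounds sharing a core that were tested in an assay on isolated protein for antagonist activity at Voltage-dependent L-type calcium channel subunit alpha-1C (Cavia porcellus), with a stated time of 15 min (on this read-out higher numbers stand for weaker inhibition and lower numbers for stronger inhibition), where compound 1 gives 21000 nM, the second highest of the three numbers. Compound 2 `CC1=C(C(=O)OCc2ccccc2)C(c2csc(-c3ccc(Cl)cc3)n2)C(C(=O)OCc2ccccc2)=C(C)N1` gives 11000 nM, which lies within the scatter of compound 1, so the two cannot be told apart. Compound 3 `COC(=O)C1=C(C)NC(C)=C(C(=O)OCC(C)C)C1c1csc(-c2ccc(Cl)cc2)n1` gives 46900 nM, beyond the scatter above compound 1, so compound 3 inhibits more weakly. Compound 4 `CCOC(=O)C1=C(C)NC(C)=C(C(=O)OC(C)(C)C)C1c1csc(-c2ccc(Cl)cc2)n1` awaits measurement. It differs from compound 1 in one place: ethyl in place of tert-butyl on an oxygen next to a carbonyl group. Among the measured compounds shown here, no measured pair shows this change, so no step beyond the scatter is expected. The expected step from compound 1 to compound 4 is a 1.2-fold higher number from compound 1 to compound 4 (0.08 log units; within the scatter). Compound 4 is estimated at 25000 nM, within a range from 8000 nM to 70000 nM.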

Compound 4, half-maximal inhibitory concentration: 91000 nM
The estimate for compound 4 lay 3.6-fold (0.56 log units) below the measured number, outside the stated range (above it).
By their numbers in this assay, from the lowest: compounds 2 and 1 (each within the scatter of the next); then compounds 3 and 4 (each within the scatter of the next).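

Replacing a single tert-butyl with ethyl on an oxygen next to a carbonyl group is not a neutral swap: inhibition weakens, with a 4.3-fold higher number from compound 1 to compound 4 (0.64 log units; beyond the scatter), a step beyond the usual scatter. The group at this place therefore matters, even though only two carbons are lost and no ring or hydrogen-bonding count changes. Nothing available here explains the step.

This single pair gives no trend across group sizes. A free carboxylic acid or a longer chain such as n-butyl at this place remains an open case.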